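The compounds below may be only part of what the source reports. "The series", "measured", "known", "first", "only" and "open" are said of these compounds alone.

Three sulfonylureas were measured in a functional assay on thoracic aorta (Rattus norvegicus, strain Wistar), with a stated time of 15 min; a lower number here means that less compound is needed, a higher number that more compound is needed for the effect. Compound 2 `Cc1ccc(S(=O)(=O)N(C)C(=O)NC(C)c2ccccc2OCc2ccccc2)cc1` gives 31000 nM, and compound 1 `CC(NC(=O)N(C)S(=O)(=O)c1ccccc1)c1ccccc1OCc1ccccc1`, which differs from it by hydrogen in place of methyl on an aromatic carbon, gives 21700 nM; the step of a 1.4-fold lower number from compound 2 to compound 1 (0.15 log units; within the scatter). Compound 3 `COc1ccc(F)cc1C(C)NC(=O)N(C)S(=O)(=O)c1ccc(C)cc1` is built on a different core, and the difference between the two cores is not broken down here. In this assay compound 3 gives 11700 nM, a number that lies within the scatter of compound 1 but beyond the scatter of compound 2. Compound 4 `COc1ccc(F)cc1C(C)NC(=O)N(C)S(=O)(=O)c1ccccc1` has not yet been measured. It differs from compound 3 by hydrogen in place of methyl on an aromatic carbon, the same change as that between compound 2 and compound 1, at the same place in the ring. Resting on the step of a 1.4-fold lower number from compound 2 to compound 1 (0.15 log units; within the scatter), which stayed within the scatter, the step expected for compound 4 is a 1.2-fold lower number from compound 3 to compound 4 (0.09 log units; within the scatter). The estimate for compound 4 in this assay is 9500 nM, expected to fall between 4000 nM and 25000 nM.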

Compound 4, half-maximal effective concentration: 10000 nM
Compound 4: middle estimate off by 1.1-fold (0.02 log units), on the low side; the range from low to high includes it.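

In this assay, the change from 4-methylphenyl to phenyl gives a 1.2-fold lower number from compound 3 to compound 4 (0.07 log units; within the scatter), and set beside the earlier step on the other core, it reads as follows: the same change on two cores in this assay, a 1.4-fold lower number (0.15 log units; within the scatter) from compound 2 to compound 1 and a 1.2-fold lower number (0.07 log units; within the scatter) from compound 3 to compound 4, 1.2-fold (0.09 log units) apart, within the scatter of two such steps. On these two cores, then, the change carries over without any difference that can be told from the scatter, and the earlier step is a fair guide to the new one. It does not show that the methyl has any real effect on the number, as each step taken alone also stays within the scatter, and two cores are too few to set a rule for the series.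

The compounds shown leave open what a group other than methyl or hydrogen would do at this place on the ring, such as a methoxy group, a chlorine atom, an amine or a carboxylic acid. They also leave open how the same change would read on a third core.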